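The compounds below may be only part of what the source reports. "The series", "measured", "known", "first", "only" and "open" are said of these compounds alone.

For the measured compounds named here, in an ADME assay on BaF3 cells (Mus musculus) for antiproliferative activity, read by CCK-8 assay, with a stated time of 72 h (a lower number here means a stronger inhibitor of growth, a higher number a weaker inhibitor of growth), compound 1 `Cc1ccc(C(=O)Nc2ccc(CN3CCN(C)CC3)c(C(F)(F)F)c2)cc1C#Cc1ncc2cccnn12` gives the lowest number so far (940 nM). Compound 2 `O=C(CCSc1ccc2c(/C=C/c3ccccn3)n[nH]c2c1)Nc1cccc(C(F)(F)F)c1` reads 2300 nM as the higher of the two numeric values, and its gap to compound 1 lies beyond the scatter. Compound 3 `CN1CCN(c2cccc(NC(=O)CCSc3ccc4c(/C=C/c5ccccn5)n[nH]c4c3)c2)CC1` returns only a limit (> 10000 nM). Compound 4 `Cc1ccc(NC(=O)CCSc2ccc3c(/C=C/c4ccccn4)n[nH]c3c2)cc1C(F)(F)F` differs from compound 2 by methyl in place of hydrogen on an aromatic carbon as methyl in place of hydrogen on an aromatic carbon, ortho to a trifluoromethyl group. Going by the values given here, the only measured step (an at least 4.3-fold higher number from compound 2 to compound 3 (0.63 log units; beyond the scatter)) replaces the trifluoromethyl group itself, which compound 4 keeps, so it gives no size for this change. In this assay no step beyond the scatter is therefore expected (a 1.2-fold lower number from compound 2 to compound 4 (0.06 log units; within the scatter)). Estimated value for compound 4: 2000 nM (expected range 800 nM to 5000 nM).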

Compound 4, concentration for 50% growth inhibition: 530 nM
The estimate for compound 4 lay 3.8-fold (0.58 log units) above the measured number, outside the stated range (below it).
By their numbers in this assay, from the lowest: compounds 4 and 1 (each within the scatter of the next); then compound 2. At a limit, above all of these: compound 3.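

Methyl on the aromatic carbon ortho to a trifluoromethyl group and para to a large group gives in this assay a 4.3-fold lower number from compound 2 to compound 4 (0.64 log units; beyond the scatter), so this carbon accepts a substituent with a gain. The earlier step, an at least 4.3-fold higher number from compound 2 to compound 3 (0.63 log units; beyond the scatter), replaced the trifluoromethyl group itself, ends at a limit and says nothing about this carbon. No value shown gives a cause for the gain.

Going by these compounds, whether the gain is specific to methyl stays open: chlorine, methoxy or an aminomethyl group on this carbon would test it. On these data alone, whether methyl still helps without the trifluoromethyl group also stays open.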